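Swapping a ring for a chain on a cytotoxic scaffold

This account rests on a few compounds, and the source may have more. Where it says the series, first, only, none or still open, it means among the compounds named here.

Of the compounds shown here, two have been measured so far in a functional assay on PC-3 cells (Homo sapiens) for cytotoxicity, read by MTT assay, with a stated time of 72 h; a lower number here means a stronger inhibitor, a higher number a weaker inhibitor. Compound 1 `[O-][n+]1nc(NCOC2CCCCC2)[n+]([O-])c2ccccc21` gives 3250 nM in this assay. Compound 2 `COc1ccc2c(c1)[n+]([O-])nc(NCOCc1ccccc1)[n+]2[O-]` carries an altered core and a different group on the oxygen, and in this assay compound 2 gives 8580 nM. Of these two numbers, compound 1 holds the lower one, and the gap between them lies beyond the usual scatter, so compound 1 is the stronger inhibitor of the pair.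

Compound 3 `CCCCCOCNc1n[n+]([O-])c2ccccc2[n+]1[O-]` has not been measured yet. It keeps the core of compound 1 and differs from it in a single place: pentyl in place of cyclohexyl on an oxygen on a saturated carbon. Among the measured compounds shown here, no measured pair differs by exactly this change, so there is no direct step to lean on. The departing ring and the arriving chain are close in counted size, so only a modest step is expected, one that could fall either way, with a slight drift toward a higher number judged somewhat more likely than a drop. Compound 3 is therefore expected to give about 4200 nM in this assay, with a plausible range from 1600 nM to 11000 nM, which corresponds to an expected step of a 1.3-fold higher number from compound 1 to compound 3 (0.11 log units; within the scatter).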

Compound 3, half-maximal inhibitory concentration: 9200 nM
The estimate for compound 3 lay 2.2-fold (0.34 log units) below the measured number, and the stated range covers the measured number.
By their numbers in this assay, from the lowest: compound 1; then compounds 2 and 3 (each within the scatter of the next).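

Putting pentyl in place of cyclohexyl, on an oxygen on a saturated carbon, gives a 2.8-fold higher number from compound 1 to compound 3 (0.45 log units; beyond the scatter) in this assay. This position therefore responds to the change, even though the departing and arriving groups are close in counted size and neither carries a hydrogen-bond donor or acceptor, so for this one pair a similar count does not mean a similar number. No measurement here tells what lies behind the step, so the presence of the ring cannot be separated from any other difference between the two groups.

The compounds shown leave open whether a smaller ring such as cyclopentyl would hold the lower number of compound 1, or whether a longer chain such as hexyl, with the count of carbons matching cyclohexyl, would stay near compound 3. They also leave open whether an amine or a carboxylic acid at the end of the chain would be tolerated on the shared core, since both groups compared here are made of carbon only.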